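This account rests on a few compounds, and the source may have more. Where it says the series, first, only, none or still open, it means among the compounds named here.

Measured compounds:
Compound 1, `O=C(Nc1cccc(-n2cc(-c3ccncc3)c(-c3cc(O)cc(Cl)c3)n2)c1)Nc1ccc(Cl)c(C(F)(F)F)c1`, gives 57%
Compound 2, `O=C(Nc1cccc(-n2cc(-c3ccncc3)c(-c3cc(O)cc(Cl)c3)n2)c1)Nc1ccc(Cl)c(Cl)c1`, gives 79%
Compound 3, `COc1cc(Cl)cc(-c2nn(-c3cccc(NC(=O)Nc4cc(C(F)(F)F)cc(C(F)(F)F)c4)c3)cc2-c2ccncc2)c1`, gives 22%

All three share one core and differ only in the groups on the outer ring of the urea. In a functional assay on MDA-MB-435 cells (Homo sapiens) for inhibition, read by sulforhodamine B assay, with a stated time of 48 h, tested at 1 uM (on this read-out lower numbers stand for a stronger effect and higher numbers for a weaker effect at the one concentration tested), compound 3 stands lowest of the three numbers, which on this read-out means the strongest effect among them; compound 1 gives a number clearly higher, and compound 2 higher still, both beyond the scatter.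

Compound 4, `COc1cc(Cl)cc(-c2nn(-c3cccc(NC(=O)Nc4cccc(C(F)(F)F)c4)c3)cc2-c2ccncc2)c1`, is the next step from compound 3: hydrogen in place of trifluoromethyl on an aromatic carbon. Of the measured steps, only one touches a trifluoromethyl on that outer ring: a number 22 percentage points higher from compound 1 to compound 2 (beyond the scatter). There, putting chloro in place of trifluoromethyl weakened the effect modestly. Taking a trifluoromethyl away altogether is a larger change than swapping it for chloro, so the expectation is a weakening of similar or somewhat greater size, that is, a higher number: a number 26 percentage points higher from compound 3 to compound 4 (beyond the scatter) is the expected step. Going by the values given here, only one such step is known, so the range is kept wide. Compound 4 is therefore estimated at 48%, expected to fall between 25% and 75%.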

Compound 4, a percentage reported as activity, at one concentration (the size of the read-out at that concentration, not a potency): 85%
Estimate against measurement, compound 4: 37 percentage points below; measured number outside the range, above it.
By their numbers in this assay, from the lowest: compound 3; then compound 1; then compounds 2 and 4 (each within the scatter of the next).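

Taking one trifluoromethyl off the outer ring of the urea, at the carbon meta to a trifluoromethyl group, gives a number 63 percentage points higher from compound 3 to compound 4 (beyond the scatter) in this assay, a large step. The earlier step showed only what happens when chloro takes the place of a trifluoromethyl on this ring, whereas this one shows that hydrogen at this carbon loses most of the effect seen for compound 3, even though the other trifluoromethyl stays in place. Nothing available explains why this single change matters so much.

On these data alone, it remains open whether trifluoromethyl itself is needed at this carbon or whether another group, such as a methyl, a nitrile or an amine, would keep the effect of compound 3. Also unsettled is whether the same change would act similarly on the core of compound 1, which carries a hydroxyl where compound 3 carries a methoxy, and since each number comes from a single concentration, none of them gives a potency.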